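Tetrazole Replaces the Triazole on the Shared Core

The source may report more compounds than this note shows. Statements on the series, on what has been measured and on what is new or still open speak of the compounds shown alone.

Among the compounds with values here, compound 1 `CCC(C)n1ncn(-c2ccc(N3CCN(c4ccc(OC[C@@H]5CO[C@@](Cn6cnc(C(F)(F)F)n6)(c6ccc(Cl)cc6Cl)O5)cc4)CC3)cc2)c1=O` gives 270 nM in a functional assay on HUVEC cells (Homo sapiens), read by scintillation counting and thymidine incorporation, with a stated time of 24 h (a lower number here means a stronger inhibitor, a higher number a weaker inhibitor), the highest of the three numbers measured so far. Compound 2 `CCc1nccn1C[C@@]1(c2ccc(Cl)cc2Cl)OC[C@@H](COc2ccc(N3CCN(c4ccc(-n5cnn(C(C)CC)c5=O)cc4)CC3)cc2)O1` gives 224 nM, and compound 3 `CCC(C)n1ncn(-c2ccc(N3CCN(c4ccc(OC[C@@H]5CO[C@@](Cn6ccnc6C(C)C)(c6ccc(Cl)cc6Cl)O5)cc4)CC3)cc2)c1=O` gives 84 nM. Compound 4 `CCC(C)n1ncn(-c2ccc(N3CCN(c4ccc(OC[C@@H]5CO[C@@](Cn6cnnn6)(c6ccc(Cl)cc6Cl)O5)cc4)CC3)cc2)c1=O` differs from compound 1 by 1H-tetrazol-1-yl in place of 3-(trifluoromethyl)-1H-1,2,4-triazol-1-yl on a saturated chain carbon bound to a saturated ring carbon. Two measured steps altered the same group on the same carbon: a 1.2-fold lower number from compound 1 to compound 2 (0.08 log units; within the scatter) and a 3.2-fold lower number from compound 1 to compound 3 (0.51 log units; beyond the scatter); between the two imidazoles, a 2.7-fold lower number from compound 2 to compound 3 (0.43 log units; beyond the scatter). Exchanging this ring for another five-membered aromatic ring has so far moved the number little or lowered it modestly, so the expected step is a 1.2-fold lower number from compound 1 to compound 4 (0.07 log units; within the scatter). Compound 4 is estimated at 230 nM, with a range from 100 nM to 600 nM.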

Compound 4, half-maximal inhibitory concentration: 73 nM
The estimate for compound 4 lay 3.2-fold (0.50 log units) above the measured number; measured number below the stated range.
By their numbers in this assay, from the lowest: compounds 4 and 3 (each within the scatter of the next); then compounds 2 and 1 (each within the scatter of the next).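

The 1H-tetrazol-1-yl on this saturated chain carbon gives a 3.7-fold lower number from compound 1 to compound 4 (0.57 log units; beyond the scatter) and a 3.1-fold lower number from compound 2 to compound 4 (0.49 log units; beyond the scatter) while a 1.2-fold lower number from compound 3 to compound 4 (0.06 log units; within the scatter) shows no separation from the 2-isopropyl-1H-imidazol-1-yl. Until now, only compound 3, with its 2-isopropyl group, had reached this low range, whereas the tetrazole reaches it with no substituent on the ring. No measurement shown accounts for this change. Still open, from the compounds shown here alone, is whether an unsubstituted 1H-imidazol-1-yl or a 1H-1,2,3-triazol-1-yl on this carbon would keep the number this low. Going by these compounds, how a carboxylic acid or an amine would behave here also remains unknown.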